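Methoxy Added to the Chloro Analogue in the Electroshock Model

The source may report more compounds than this note shows. Statements on the series, on what has been measured and on what is new or still open speak of the compounds shown alone.

Four cinnamamides of two closely related cores are compared in a functional assay on the whole organism (Hindlimb, strain albino) with Mus musculus as the target, in the maximal electroshock model, with a stated time of 0.5 h; a lower number here means that less compound is needed, a higher number that more compound is needed for the effect. Compound 1 `COc1ccc(/C=C/C(=O)Nc2nc3ccc([N+](=O)[O-])cc3s2)cc1` gives 315 umol/kg, compound 2 `O=C(/C=C/c1ccccc1)Nc1nc2ccc([N+](=O)[O-])cc2s1` gives 485 umol/kg and compound 3 `O=C(/C=C/c1ccccc1)Nc1nc2ccc(Cl)cc2s1` gives 425 umol/kg. The two cores differ by chloro in place of nitro on an aromatic carbon, and the step of a 1.1-fold lower number from compound 2 to compound 3 (0.06 log units; within the scatter). The change from compound 2 to compound 1 is methoxy in place of hydrogen on an aromatic carbon, and it made a 1.5-fold lower number from compound 2 to compound 1 (0.19 log units; within the scatter). Compound 4 `COc1ccc(/C=C/C(=O)Nc2nc3ccc(Cl)cc3s2)cc1` carries the same change on the core of compound 3: methoxy in place of hydrogen on an aromatic carbon, at the same place as before. The step from compound 3 to compound 4 is expected to be a 1.5-fold lower number from compound 3 to compound 4 (0.17 log units; within the scatter), resting on the earlier step of a 1.5-fold lower number from compound 2 to compound 1 (0.19 log units; within the scatter) and on the near-equal values of compound 2 and compound 3. Compound 4 is therefore estimated at 290 umol/kg, between 170 umol/kg and 500 umol/kg.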

Compound 4, dose for half-maximal effect: 259 umol/kg
For compound 4 the middle estimate is 1.1-fold (0.05 log units) above the measured one; the range from low to high includes it.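

In this assay the methoxy change gives a 1.6-fold lower number from compound 3 to compound 4 (0.22 log units; within the scatter) and thus carries from one core to the other without a difference beyond the scatter: the same change on two cores in this assay, a 1.5-fold lower number (0.19 log units; within the scatter) from compound 2 to compound 1 and a 1.6-fold lower number (0.22 log units; within the scatter) from compound 3 to compound 4, 1.1-fold (0.03 log units) apart, within the scatter of two such steps. The exchange of nitro for chloro, which gives a 1.2-fold lower number from compound 1 to compound 4 (0.09 log units; within the scatter) on the methoxy compounds, agrees in the same way with its earlier step: the same change on two cores in this assay, a 1.1-fold lower number (0.06 log units; within the scatter) from compound 2 to compound 3 and a 1.2-fold lower number (0.09 log units; within the scatter) from compound 1 to compound 4, 1.1-fold (0.03 log units) apart, within the scatter of two such steps. All these steps lie within the scatter, so the series shows agreement between small steps on two cores, but it does not show that methoxy in place of hydrogen changes the number on either core.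

The compounds shown leave open whether another group at the same place, such as an amine or a carboxylic acid, would give a step beyond the scatter. They also leave open whether the agreement would hold on a core bearing neither nitro nor chloro.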